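This account rests on a few compounds, and the source may have more. Where it says the series, first, only, none or still open, it means among the compounds named here.

Two compounds have a measurement:
compound 1, `COc1ccc2[nH]c(C(=O)N3CC(=O)N(Cc4ccccc4)[C@@H](CCN4CCC5(CC4)CC5)C3)cc2c1`, with > 25000 nM
compound 2, `Cc1ccc2[nH]c(C(=O)N3CC(=O)N(Cc4ccccc4)[C@@H](CN4CCC5(CCC5)CC4)C3)cc2c1`, with 12300 nM

In a physicochemical assay for solubility, read by spectrophotometry, in phosphate buffer, with a stated time of 2 h, at pH 7.4 (a higher number here means a more soluble compound, a lower number a less soluble compound), compound 1 gives > 25000 nM, which is a limit of the assay rather than a number. Where compound 1 stands is therefore known only as the limit of > 25000 nM in this assay, at which 1 of the 2 values shown sits. In this assay compound 2 gives 12300 nM. Going by the values given here, no two measured compounds differ in one place only, so no measured step is available to lean on.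

Compound 3, `COc1ccc2[nH]c(C(=O)N3CC(=O)N(Cc4ccccc4)[C@@H](CN4CCc5ccccc5C4)C3)cc2c1`, is not yet measured. It differs from compound 1 in one place: a group of 10 heavy atoms (9 carbon, 1 nitrogen; one six-membered non-aromatic ring with 1 hetero atom, one six-membered aromatic ring of carbon only) in place of a group of 9 heavy atoms (8 carbon, 1 nitrogen; one three-membered non-aromatic ring of carbon only, one six-membered non-aromatic ring with 1 hetero atom), on a saturated chain carbon bound to a saturated ring carbon. The entering group brings one six-membered aromatic ring of carbon only in place of one three-membered non-aromatic ring of carbon only. Among the compounds with values here, with no measured step to guide it, the expected step is an at least 2.5-fold lower number from compound 1 to compound 3 (0.39 log units; beyond the scatter), a fall that may reach beyond the usual scatter. Compound 3 is estimated at 10000 nM, with a range from 2500 nM to 25000 nM.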

Compound 3, solubility: 9000 nM
Compound 3: the middle estimate sits 1.1-fold (0.05 log units) above what was measured, and the stated range covers the measured number.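

Putting 1,2,3,4-tetrahydroisoquinolin-2-yl in place of the group with the three-membered carbon ring, on a saturated chain carbon bound to a saturated ring carbon, gives an at least 2.7-fold lower number from compound 1 to compound 3 (0.44 log units; beyond the scatter) in this assay. Going by these compounds alone, this is the only measured step here, and it shows that this place does not tolerate every change without a shift beyond the scatter, even though the counts of hydrogen-bond donors and acceptors and the net charge of the two groups are the same. The true size of the step stays unknown because it starts from a value that is a limit and not a number: the limit of > 25000 nM in this assay, at which 1 of the 3 values shown sits.

This single step cannot separate the arrival of the aromatic ring from the loss of the three-membered ring. On these data alone, how a morpholine ring or a carboxylic acid at this place would read also remains open.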